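A few compounds are considered here, and "the series" means these few. Any claim that something is new, unique, unknown or untested is made for them only; others in the source may bear on it.

Measured in a functional assay on HeLa cells (Homo sapiens) for cytotoxicity, read by MTT assay, with a stated time of 48 h; on this read-out higher numbers stand for weaker inhibition and lower numbers for stronger inhibition:
- Compound 1 `O=C(O)CN1C(=O)/C(=C/c2nc3ccccc3n2Cc2ccccc2)SC1=S`: 22700 nM
- Compound 2 `Cc1ccc(Cn2c(/C=C3\SC(=S)N(CC(=O)O)C3=O)nc3ccccc32)cc1`: 1280 nM
- Compound 3 `O=C(O)CN1C(=O)/C(=C/c2nc3ccccc3n2Cc2ccc(Cl)cc2)SC1=S`: 8720 nM

Of these three, compound 3 takes the middle place, at 8720 nM. Compound 1 has the highest number and compound 2 the lowest, and both gaps to compound 3 lie beyond the scatter.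

Compound 4 `O=C(O)CN1C(=O)/C(=C/c2nc3ccccc3n2Cc2ccc(F)c(F)c2)SC1=S` has not yet been measured. Its difference from compound 3 is 3,4-difluorophenyl in place of 4-chlorophenyl on a saturated chain carbon bound to an aromatic nitrogen, with 3,4-difluorophenyl in place of 4-chlorophenyl on a saturated chain carbon bound to an aromatic nitrogen.

For the measured compounds named here, no measured compound carries fluorine, so no step speaks to this change directly. The closest guide is chloro in place of hydrogen, a 2.6-fold lower number from compound 1 to compound 3 (0.42 log units; beyond the scatter). Methyl in place of hydrogen gave a larger move, an 18-fold lower number from compound 1 to compound 2 (1.25 log units; beyond the scatter), and chloro in place of methyl gave a 6.8-fold higher number from compound 2 to compound 3 (0.83 log units; beyond the scatter). These steps show that substitution on this aromatic ring can shift the number considerably, but they give no direction for the swap from chloro to two fluoro groups.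

In this assay, no step beyond the scatter is therefore expected, although a modest move either way remains possible. The expected step is a 1.1-fold lower number from compound 3 to compound 4 (0.04 log units; within the scatter). The estimate for compound 4 is 8000 nM, with an expected range from 2500 nM to 25000 nM.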

Compound 4, half-maximal inhibitory concentration: 16000 nM
Estimate against measurement, compound 4: 2.0-fold (0.30 log units) below, within the range that was stated.
By their numbers in this assay, from the lowest: compound 2; then compounds 3, 4 and 1 (each within the scatter of the next, the first and the last beyond it).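

In this assay, 3,4-difluorophenyl in place of 4-chlorophenyl, on a saturated chain carbon bound to an aromatic nitrogen, gives a step that cannot be separated from the scatter (a 1.8-fold higher number from compound 3 to compound 4 (0.26 log units; within the scatter)), and the same holds for 3,4-difluorophenyl in place of phenyl (a 1.4-fold lower number from compound 1 to compound 4 (0.15 log units; within the scatter)). Against 4-methylphenyl, by contrast, the change is large (a 13-fold higher number from compound 2 to compound 4 (1.10 log units; beyond the scatter)), so compound 2 is now the only one of the four with a number beyond the scatter of all the others, and a substituted ring at this position does not by itself bring a large step. Nothing measured on these groups accounts for this result.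

The compounds shown leave open whether the large step belongs to the methyl group alone or extends to other small groups on this ring, such as ethyl, methoxy or trifluoromethyl. They also leave open how a single fluoro group, or an amine on the ring, would compare with the 3,4-difluorophenyl of compound 4.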